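This account rests on a few compounds, and the source may have more. Where it says the series, first, only, none or still open, it means among the compounds named here.

Compound 1 `O=[N+]([O-])c1ccc(-c2csc(Nc3n[nH]c(=S)n3-c3ccccc3)n2)cc1` is one of three measured compounds built on a shared core. In a functional assay on the whole organism (strain Swiss albino) for inhibition, with Mus musculus as the target, with a stated time of 4 h (on this read-out lower numbers stand for an effect already at smaller amounts and higher numbers for an effect only at larger amounts of compound), compound 1 gives 300 mg/kg. Compound 2 `S=c1[nH]nc(Nc2nc(-c3ccc(Br)cc3)cs2)n1-c1ccccc1` carries bromo in place of nitro on an aromatic carbon and gives 300 mg/kg; compound 3 `S=c1[nH]nc(Nc2nc(-c3ccc(Cl)cc3)cs2)n1-c1ccccc1` carries chloro in place of nitro on an aromatic carbon and gives 300 mg/kg. The step of no change at the digits printed from compound 1 to compound 2 (within the scatter) and the step of no change at the digits printed from compound 1 to compound 3 (within the scatter) both stay within the scatter, as does no change at the digits printed from compound 2 to compound 3 (within the scatter), so compound 1 stands level with compounds 2 and 3 at the digits shown.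

Compound 4 `COc1ccc(-n2c(Nc3nc(-c4ccc([N+](=O)[O-])cc4)cs3)n[nH]c2=S)cc1` has not yet been measured. It differs from compound 1 by methoxy in place of hydrogen on an aromatic carbon. Within the data shown here, none of the measured steps concerns this kind of change: all three swap nitro, bromo and chloro among one another, and none of them moved the read-out beyond the scatter. Among the measured compounds shown here, there is thus no measured step that bears directly on the change from compound 1 to compound 4, and three variations without any shift give no ground to expect one here. The step of no change at the digits printed from compound 1 to compound 4 (within the scatter) is therefore expected to be none beyond the scatter. Compound 4 is estimated at 300 mg/kg, with a range from 150 mg/kg to 600 mg/kg.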

Compound 4, minimum effective dose: 300 mg/kg
The estimate for compound 4 equals the measured number at the digits printed; measured number inside the range.
By their numbers in this assay, from the lowest: compounds 1, 2, 3 and 4 (each within the scatter of the next).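

Among these compounds, compound 4 moves the variation to a second place: the earlier steps only exchanged nitro, bromo and chloro at one place, whereas here phenyl becomes 4-methoxyphenyl. In this assay, adding methoxy on an aromatic carbon, para to a large group, gives no change at the digits printed from compound 1 to compound 4 (within the scatter), so this position accepts a group of 2 heavy atoms, one of them an oxygen, with no shift beyond the scatter. No measurement is at hand that would account for this result.

The compounds shown leave open whether an amine, a carboxylic acid or a longer chain such as butoxy at this same place would also leave the read-out within the scatter, or whether any of them would shift it in either direction. They also leave open whether methoxy would behave the same way with bromo or chloro in place of nitro, since it appears here only alongside nitro, and no change in this series has yet moved the read-out beyond the scatter.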